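The compounds below may be only part of what the source reports. "The series", "measured", "known", "first", "only" and "open" are said of these compounds alone.

In a functional assay on Raji cells (Homo sapiens) for cytotoxicity, with a stated time of 72 h (on this read-out lower numbers stand for stronger inhibition and higher numbers for weaker inhibition), compound 1 `CCOC(=O)/C=C/C=C/C=C/c1ccc[nH]1` gives > 10000 nM, which is a limit and not a number. Compound 2 `CCOC(=O)/C=C/C=C/C=C/c1ccco1` also gives only a limit, > 10000 nM. This is the limit of > 10000 nM in this assay, at which 2 of the 3 values shown sit. Compound 3 `O=C(/C=C/C=C/C=C/c1ccc[nH]1)c1ccccc1` reads 9890 nM. Compound 4 `O=C(/C=C/C=C/C=C/c1ccc[nH]1)OCc1ccccc1` carries one change from compound 1: phenyl in place of methyl on a saturated chain carbon bound to an oxygen next to a carbonyl group. Among the compounds with values here, two measured steps bear on it, and neither has a readable size: a step that the two limits leave unreadable from compound 1 to compound 2 and a number no higher from compound 1 to compound 3 (the limit leaves the size open). The second is the closer guide, since it also brings in phenyl, though on a carbonyl carbon. A small expected shift toward stronger inhibition in this assay is therefore estimated, an at least 1.1-fold lower number from compound 1 to compound 4 (0.04 log units; that floor lies within the scatter). For compound 4 the expected value is 9000 nM, within an estimated range of 3000 nM to 20000 nM.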

Compound 4, half-maximal inhibitory concentration: > 10000 nM
Compound 4 gave a limit, no number (the forecaster's own chance of this, stated with the estimate: 50%); middle value at least 1.1-fold (0.04 log units) away from the limit.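

Compound 4, like compound 1, gives only a limit, so no new step can be read between them: the limit of > 10000 nM in this assay, at which 3 of the 4 values shown sit. The compounds shown leave open whether going from ethyl to benzyl shifts inhibition at all, and by how much.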